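Amide in place of acid on a weakly active scaffold

This account rests on a few compounds, and the source may have more. Where it says the series, first, only, none or still open, it means among the compounds named here.

Compound 1 `O=C(O)/C=C/c1ccncc1-c1ccc2cc[nH]c2c1` is the carboxylic acid of this small set. In a functional assay on MCF7 cells (Homo sapiens) for inhibition, read by sulforhodamine B assay, with a stated time of 72 h (a lower number here means a stronger inhibitor of growth, a higher number a weaker inhibitor of growth), compound 1 gives > 10000 nM, which is a limit of the assay rather than a number. Compound 2 `CNC(=O)/C=C/c1ccncc1-c1ccc2c(cnn2C)c1` also gives only a limit, > 10000 nM, in this assay. Within the data shown here, compound 3 `O=C(/C=C/c1ccncc1-c1ccc2ccccc2c1)NC1CC1` is the one member with a measured number, 6840 nM in this assay. Because (the limit of > 10000 nM in this assay, at which 2 of the 3 values shown sit), compound 1 stands where most of the set stands, at the edge of what the assay can report. Compound 4 `CNC(=O)/C=C/c1ccncc1-c1ccc2cc[nH]c2c1` differs from compound 1 by methylamino in place of hydroxy on a carbonyl carbon. No measured step of this kind is shown, so the expected change in this assay is small and uncertain in direction, likely within the scatter. Compound 4 is therefore expected to give about 12000 nM, within 4000 nM to 40000 nM, a step that the limit leaves unreadable from compound 1 to compound 4 that may again end as a limit.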

Compound 4, concentration for 50% growth inhibition: 9230 nM
Compound 4: the middle estimate sits 1.3-fold (0.11 log units) above what was measured; the range from low to high includes it.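

With methylamino in place of hydroxy on the carbonyl carbon, the shared core gives a readable number in this assay, and the change reads as an at least 1.0-fold lower number from compound 1 to compound 4 (0.03 log units; that floor lies within the scatter). On these data alone, that figure is only a floor, so the true size of the step remains unknown. Compound 1 itself stays at a limit, as does one other member of the set: the limit of > 10000 nM in this assay, at which 2 of the 4 values shown sit.

The compounds shown leave open how far this step extends beyond its floor. They also leave open how this core responds to amino or dimethylamino on the same carbonyl carbon.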